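Changing the Acylurea Aryl Ring of Compound 1

The source may report more compounds than this note shows. Statements on the series, on what has been measured and on what is new or still open speak of the compounds shown alone.

Compound 1 `CN(C(=O)NC(=O)c1ccc(Cl)cc1Cl)c1nc(C(F)(F)F)c(C(=O)N/N=C/c2cccc(C(F)(F)F)c2)s1` gives 10.7 ug/mL in a functional assay on MCF7 cells (Homo sapiens) for inhibition, read by MTT assay, with a stated time of 72 h; on this read-out higher numbers stand for weaker inhibition and lower numbers for stronger inhibition.
Compound 2 `CN(C(=O)NC(=O)c1ccc(Cl)cc1Cl)c1nc(C(F)(F)F)c(C(=O)N/N=C/c2cc(C(F)(F)F)cc(C(F)(F)F)c2)s1` gives > 100 ug/mL in this assay.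
Compound 3 `CN(C(=O)NC(=O)c1ccc(Cl)cc1Cl)c1nc(C(F)(F)F)c(C(=O)N/N=C/c2ccccc2C(F)(F)F)s1` gives 9.12 ug/mL in this assay.

Compound 1 holds the highest of the two plain numbers, but compound 3 sits within the scatter of it: a 1.2-fold lower number from compound 1 to compound 3 (0.07 log units; within the scatter). For compound 2 the result is a limit of the assay rather than a number (the limit of > 100 ug/mL in this assay, at which 1 of the 3 values shown sits). That step is large: an at least 9.3-fold higher number from compound 1 to compound 2 (0.97 log units; beyond the scatter).

Compound 4 `CN(C(=O)NC(=O)c1cccc(C(F)(F)F)c1)c1nc(C(F)(F)F)c(C(=O)N/N=C/c2cccc(C(F)(F)F)c2)s1` differs from compound 1 elsewhere: 3-(trifluoromethyl)phenyl in place of 2,4-dichlorophenyl on a carbonyl carbon. Both measured steps alter the ring on the carbon with a double bond to nitrogen, not the carbonyl-bound ring, so none bears directly on this change; no shift beyond the scatter in this assay is expected. Compound 4 is estimated at 12 ug/mL, ranging from 4 ug/mL to 40 ug/mL, an expected 1.1-fold higher number from compound 1 to compound 4 (0.05 log units; within the scatter).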

Compound 4, half-maximal inhibitory concentration: 3.7 ug/mL
Compound 4: the middle estimate sits 3.2-fold (0.51 log units) above what was measured, outside the stated range (below it).
By their numbers in this assay, from the lowest: compound 4; then compounds 3 and 1 (each within the scatter of the next). At a limit, above all of these: compound 2.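

In this assay, going by these compounds alone, the ring on the carbonyl carbon proves able to shift the read-out: 3-(trifluoromethyl)phenyl in place of 2,4-dichlorophenyl gives a 2.9-fold lower number from compound 1 to compound 4 (0.46 log units; beyond the scatter), a modest move toward stronger inhibition, whereas the earlier steps changed only the other ring. Nothing given here explains this shift. The compounds shown leave open whether the change follows from losing the chlorine atoms or from gaining the trifluoromethyl group. They also leave open how a plain phenyl, or a phenyl carrying an amine or a carboxylic acid, would read on this carbonyl carbon.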